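Hydrogen in place of methyl on compound 3

This account rests on a few compounds, and the source may have more. Where it says the series, first, only, none or still open, it means among the compounds named here.

Three related compounds have been measured in an ADME assay on liver for metabolic stability, with Liver microsome (Homo sapiens) as the target, read by LC-MS, using microsomes, with a stated time of 5 h; a lower number here means slower removal, a higher number faster removal of the compound. Compound 1 (`OC(c1ccccn1)C1(c2ccc(Cl)c(Cl)c2)COC1`) gives 133 mL/min/kg, and compound 2 (`O[C@H](c1ccccn1)C1(c2ccc(OC(F)(F)F)cc2)CC(F)(F)C1`) gives 183 mL/min/kg. Compound 3 (`CN1CC(c2ccc(C(F)(F)F)cc2)(C(O)c2ccccn2)C1`) gives 50 mL/min/kg, the lowest of the three and beyond the usual scatter from both others. Compound 4 (`OC(c1ccccn1)C1(c2ccc(C(F)(F)F)cc2)CNC1`) differs from compound 3 in one place: hydrogen in place of methyl on an amine nitrogen in a ring. Among the compounds with values here, no measured pair shows this change, so the expectation is loose: a small step toward lower clearance in this assay, likely within the scatter. The expected step runs a 1.3-fold lower number from compound 3 to compound 4 (0.12 log units; within the scatter). The estimated clearance of compound 4 is 38 mL/min/kg, with an expected range of 16 mL/min/kg to 85 mL/min/kg.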

Compound 4, clearance: 33.3 mL/min/kg
For compound 4 the middle estimate is 1.1-fold (0.06 log units) above the measured one; the range from low to high includes it.
By their numbers in this assay, from the lowest: compounds 4 and 3 (each within the scatter of the next); then compounds 1 and 2 (each within the scatter of the next).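

This is the only pair shown that differs in one place. In this assay, hydrogen in place of methyl on the amine nitrogen in the ring gives a 1.5-fold lower number from compound 3 to compound 4 (0.18 log units; within the scatter), so on these numbers clearance does not separate the two groups at this position. Nothing available bears on why this is so. Still open, going by these compounds, is how clearance responds to a larger group on this nitrogen, such as an acetyl group or a longer chain. Also open, on these data alone, is whether this swap gives the same result with a different group on the phenyl ring.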